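The source may report more compounds than this note shows. Statements on the series, on what has been measured and on what is new or still open speak of the compounds shown alone.

Working notes on the series. The read-out throughout is a functional assay on the whole organism (strain Swiss) with Mus musculus as the target, in the maximal electroshock model, with a stated time of 2 h, at a dose of 300 mg/kg by the intraperitoneal route; a higher number here means a stronger effect of the compound at the dose given, a lower number a weaker effect. Compound 1 `CC(C(=O)N1CCN(c2ccc(Cl)cc2)CC1)N1C(=O)CCC1=O` gives 0% in this assay, and compound 2 `CCC(C(=O)N1CCN(c2ccccc2Cl)CC1)N1C(=O)CCC1=O` gives 0%. Compound 3 `CC(C(=O)N1CCN(c2ccc(F)cc2)CC1)N1C(=O)CCC1=O` gives 50%, which is the highest of the three numbers; the nearest is compound 1 and the furthest compound 2, both the same distance below and both beyond the scatter. Going by the values given here, the only single-point step so far is a number 50 percentage points higher from compound 1 to compound 3 (beyond the scatter), a large gain in this assay.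

Compound 4 `CC(C(=O)N1CCN(c2ccccc2Cl)CC1)N1C(=O)CCC1=O` is reached from compound 3 by 2-chlorophenyl in place of 4-fluorophenyl on an amine nitrogen in a ring. The measured step of a number 50 percentage points higher from compound 1 to compound 3 (beyond the scatter) bears on this in reverse, chloro returning in place of fluoro, and points to a large fall in this assay. Nothing measured separates 2-chlorophenyl from 4-chlorophenyl; compound 2, which also carries 2-chlorophenyl, gives 0%. Compound 4 is therefore expected to give 10%, within 0% to 35%. The estimated step from compound 3 to compound 4 is a number 40 percentage points lower from compound 3 to compound 4 (beyond the scatter).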

Compound 4, a percentage reported as activity, at one dose (the size of the read-out at that dose, not a potency): 0%
The estimate for compound 4 lay 10 percentage points above the measured number; low and high end bracket the measured number.
By their numbers in this assay, from the lowest: compounds 1, 2 and 4 (each within the scatter of the next); then compound 3.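

On the amine nitrogen in a ring, 2-chlorophenyl in place of 4-fluorophenyl gives a number 50 percentage points lower from compound 3 to compound 4 (beyond the scatter) in this assay, while 2-chlorophenyl in place of 4-chlorophenyl gives no change at the digits printed from compound 1 to compound 4 (within the scatter). The two chlorophenyl groups are thus not told apart here, and both stand well under 4-fluorophenyl. Hydrogen in place of methyl on the saturated chain carbon gives no change at the digits printed from compound 2 to compound 4 (within the scatter), but with all three chlorophenyl compounds at the bottom of the read-out, a further loss could not show, and nothing on hand accounts for the gap between 4-fluorophenyl and the chlorophenyl groups.

On these data alone, whether the gain belongs to 4-fluorophenyl alone remains open; unsubstituted phenyl, 2-fluorophenyl or 4-methoxyphenyl on the same nitrogen would bear on this. Also open, as far as these compounds go, is whether the chain change, or a longer chain, matters once 4-fluorophenyl is present.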